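The source may report more compounds than this note shows. Statements on the series, on what has been measured and on what is new or still open speak of the compounds shown alone.

Measured in an assay on cells for inhibition of Voltage-dependent T-type calcium channel subunit alpha-1H (Homo sapiens), read by FLIPR and calcium flux, with stated times of 600 s and 300 s; on this read-out lower numbers stand for stronger inhibition and higher numbers for weaker inhibition:
compound 1 `NCCCOc1ccc(CNc2nc3ccc(Oc4ccc(C(F)(F)F)cc4)cc3s2)cc1` gives 112000 nM
compound 2 `CN(Cc1ccc(OCCCN)cc1)c1nc2ccc(Oc3ccc(C(F)(F)F)cc3)cc2s1` gives 248000 nM
compound 3 `N=C(N)NCCCOc1ccc(CNc2nc3ccc(Oc4ccc(C(F)(F)F)cc4)cc3s2)cc1` gives 195000 nM

Compound 1 has the lowest number of the three in this assay; compound 3 sits within the scatter of it, as the step of a 1.7-fold higher number from compound 1 to compound 3 (0.24 log units; within the scatter) shows, while the step of a 2.2-fold higher number from compound 1 to compound 2 (0.35 log units; beyond the scatter) lies just beyond it. Compound 4 `NCCCOc1ccc(CNc2nc3ccc(Oc4ccccc4)cc3s2)cc1` differs from compound 1 by hydrogen in place of trifluoromethyl on an aromatic carbon. Among the compounds with values here, neither measured step touches this part of the molecule: one changes the nitrogen on the aromatic ring, the other the amine end of the chain, so no step bears on the change to compound 4. With no guide, the number for compound 4 is expected near that of compound 1, the step of a 1.6-fold higher number from compound 1 to compound 4 (0.21 log units; within the scatter) being an estimate only. Compound 4 is therefore estimated at 180000 nM, within 60000 nM to 500000 nM.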

Compound 4, half-maximal inhibitory concentration: > 1000000 nM
Compound 4 gave a limit, no number; the forecaster's own chance of this, stated with the estimate: 35%; at least 5.5-fold (0.74 log units) between middle value and limit.
By their numbers in this assay, from the lowest: compounds 1, 3 and 2 (each within the scatter of the next, the first and the last beyond it). At a limit, above all of these: compound 4.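

In this assay compound 4 gives > 1000000 nM, which is a limit of the assay and not a number. Within the data shown here, the change from 4-(trifluoromethyl)phenoxy to phenoxy comes with an at least 8.9-fold higher number from compound 1 to compound 4 (0.95 log units; beyond the scatter), the first evidence that the read-out responds to this end of the molecule, whereas the earlier steps concerned only the nitrogen on the aromatic ring and the amine end of the chain. The true size of this step stays open, as the reading reaches the top of the range: the limit of > 1000000 nM in this assay, at which 1 of the 4 values shown sits.

Going by these compounds, whether a chlorine atom, a methyl or a methoxy at this carbon would hold the number of compound 1 remains open. So does whether a group larger than trifluoromethyl, such as pentafluoroethyl, would lower it.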